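This account rests on a few compounds, and the source may have more. Where it says the series, first, only, none or still open, it means among the compounds named here.

Compound 1 `CSc1nc(O)cc(C(C)c2c(F)cccc2F)n1`, compound 2 `CC(C)Sc1nc(O)cc(C(C)c2c(F)cccc2F)n1` and compound 3 `CCCCSc1nc(O)cc(C(C)c2c(F)cccc2F)n1` share one core and differ only in the group attached to the sulfur. In a functional assay on MT4 cells (Homo sapiens) for cytotoxicity (a higher number here means that more compound is tolerated, a lower number that less compound is tolerated), compound 1 gives 20800 nM and compound 2 gives 167000 nM. For compound 3 only a limit of the assay is known, > 200000 nM. Compound 3 therefore stands at the top of the measured range, at the limit of > 200000 nM in this assay, at which 1 of the 3 values shown sits. Compound 4 `CC(C)CSc1nc(O)cc(C(C)c2c(F)cccc2F)n1` is the next step, with isopropyl in place of propyl on a saturated chain carbon bound to a sulfur. Both earlier changes raised the number: an 8.0-fold higher number from compound 1 to compound 2 (0.90 log units; beyond the scatter) and an at least 9.6-fold higher number from compound 1 to compound 3 (0.98 log units; beyond the scatter), whereas an at least 1.1-fold higher number from compound 2 to compound 3 (0.07 log units; that floor lies within the scatter). With compound 3 already at the limit, a step of a number no higher from compound 3 to compound 4 (the limit leaves the size open) is expected, meaning no shift beyond the scatter. Compound 4 is estimated at 200000 nM, between 100000 nM and 400000 nM.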

Compound 4, half-maximal cytotoxic concentration: > 200000 nM
Compound 4 gave a limit, no number; the forecaster's own chance of this, stated with the estimate: 70%; the middle value sits exactly at the limit.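

Swapping butyl for isobutyl on the sulfur leaves the compound at the top of the range: the limit of > 200000 nM in this assay, at which 2 of the 4 values shown sit.

Set against methyl, the change gives an at least 9.6-fold higher number from compound 1 to compound 4 (0.98 log units; beyond the scatter), while isobutyl in place of isopropyl gives an at least 1.1-fold higher number from compound 2 to compound 4 (0.07 log units; that floor lies within the scatter). Compound 3 and compound 4 are both limits, so the step between them cannot be read.

As far as these compounds go, how far either compound lies past that limit stays open, so the effect of chain shape cannot be judged in this assay. From the compounds shown here alone, whether a longer chain, or an amine in place of the chain, would keep the number this high is also open.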